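Aryl urea variation in a quinolinone GnRH antagonist series

The compounds below may be only part of what the source reports. "The series", "measured", "known", "first", "only" and "open" are said of these compounds alone.

Three compounds of one core have numbers in a functional assay on cells (Pituitary gland cell) for antagonist activity at Gonadotropin-releasing hormone receptor (Rattus norvegicus); on this read-out higher numbers stand for weaker inhibition and lower numbers for stronger inhibition. Compound 1 `Cc1cc(-c2c(O)nc3cc(Cl)c([N+](=O)[O-])cc3c2OCCC2CCCCN2)cc(C(C)O)c1` gives 63 nM. For the measured compounds named here, compound 2 `O=[N+]([O-])c1cc2c(OCCC3CCCCN3)c(-c3cc(Cl)cc(Cl)c3)c(O)nc2cc1Cl` gives 24 nM; the single step of a 2.6-fold lower number from compound 1 to compound 2 (0.42 log units; beyond the scatter) is the only one-point change measured so far. Compound 3 `Cc1cc(C)cc(-c2c(O)nc3cc(Cl)c(NC(=O)Nc4cccnc4)cc3c2OCCC2CCCCN2)c1` gives 20 nM, the lowest of the three numbers, though it lies within the scatter of compound 2 and is separated beyond the scatter only from compound 1.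

The next compound, compound 4 `Cc1cc(C)cc(-c2c(O)nc3cc(Cl)c(NC(=O)Nc4ncccn4)cc3c2OCCC2CCCCN2)c1`, keeps everything of compound 3 except the ring on the ((pyridin-3-yl)carbamoyl)amino group: pyrimidin-2-yl in place of pyridin-3-yl on an amide-type nitrogen.

Going by the values given here, no measured step touches this part of the molecule. Among the compounds with values here, the one step in hand, from compound 1 to compound 2, concerns the aryl group on the aromatic carbon, not the amide-type nitrogen, so it gives no direct guide to the size or direction of the present change. With nothing to suggest a shift, the working expectation is a step within the scatter in this assay, and a 1.3-fold higher number from compound 3 to compound 4 (0.10 log units; within the scatter) is estimated as essentially flat. For compound 4 the value in this assay is expected at about 25 nM, with a range from 8 nM to 80 nM.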

Compound 4, half-maximal inhibitory concentration: 6 nM
Beside the measured number, compound 4's estimate is 4.2-fold (0.62 log units) above it; the whole stated range lies above it.
By their numbers in this assay, from the lowest: compound 4; then compounds 3 and 2 (each within the scatter of the next); then compound 1.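

In this assay, for the compounds shown here, a 3.3-fold lower number from compound 3 to compound 4 (0.52 log units; beyond the scatter) is the first measured change at this place, and it shows that the ring on the amide-type nitrogen affects the read-out: replacing pyridin-3-yl with pyrimidin-2-yl moves the number beyond the scatter, although the heavy-atom count stays the same. The exchange changes two things at once, the number of ring hetero atoms and the naming position at which the ring is attached, and this single step cannot separate them. No available evidence bears on why the number falls with this change.

The compounds shown leave open whether the second ring nitrogen or the attachment position carries the step, a question that pyridin-2-yl and pyrimidin-5-yl on the same nitrogen would address, while plain phenyl or a saturated ring such as cyclohexyl would test whether any ring nitrogen is needed at all. They also leave open whether the same exchange gives a step of similar size when the 3,5-dimethylphenyl group shared by compound 3 and compound 4 is replaced by the 3,5-dichlorophenyl group of compound 2.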